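This account rests on a few compounds, and the source may have more. Where it says the series, first, only, none or still open, it means among the compounds named here.

Working notes on the series.

Three compounds share a core and differ only in the aryl group on its saturated ring carbon. Compound 1 `COc1ccc(C2SCC(=O)N2CCN2CCCCC2)cc1` carries a methoxy on its aromatic ring, compound 2 `O=C1CSC(c2ccc(F)cc2)N1CCN1CCCCC1` and compound 3 `O=C1CSC(c2cccc(F)c2)N1CCN1CCCCC1` a fluoro. In an ADME assay on Vero cells (Chlorocebus sabaeus) for cytotoxicity, read by neutral red uptake, tested at 25 ug/mL (a lower number here means a stronger effect, a higher number a weaker effect of the compound at the concentration tested), compound 1 gives 100%, compound 2 gives 100% and compound 3 gives 100%; none of the three shows an effect at the concentration tested.

The change methoxy in place of fluoro on an aromatic carbon makes the step of no change at the digits printed from compound 2 to compound 1 (within the scatter). The cores of compound 2 and compound 3 differ by 3-fluorophenyl in place of 4-fluorophenyl on a saturated ring carbon, and this makes the step of no change at the digits printed from compound 2 to compound 3 (within the scatter). Compound 3 therefore stands level with compound 1 and compound 2 in this assay.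

Compound 4 `COc1cccc(C2SCC(=O)N2CCN2CCCCC2)c1` has not been measured. It differs from compound 3 by methoxy in place of fluoro on an aromatic carbon. Among the measured compounds shown here, this is the same kind of change as the one from compound 2 to compound 1, but not the same: in the earlier pair the group sits para to a large group, here it sits meta to a large group. In this assay the step from compound 3 to compound 4 is expected to be no change at the digits printed from compound 3 to compound 4 (within the scatter), because the same kind of change gave no change at the digits printed from compound 2 to compound 1 (within the scatter) and because compound 3 already gives 100%, leaving no room for a weaker effect to register. Compound 4 is thus estimated at 100%, with the range 90% to 100%.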

Compound 4, a percentage reported as activity, at one concentration (the size of the read-out at that concentration, not a potency): 97%
The estimate for compound 4 lay 3 percentage points above the measured number; the measured number falls inside the stated range.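

In this assay, methoxy in place of fluoro on an aromatic carbon gives a number 3 percentage points lower from compound 3 to compound 4 (within the scatter). Set beside the earlier step, the change carries from one core to the other with no difference that can be told apart: the same change on two cores in this assay, no change at the digits printed (within the scatter) from compound 2 to compound 1 and a number 3 percentage points lower (within the scatter) from compound 3 to compound 4, 3 percentage points apart, within the scatter of two such steps

This does not show that the change is inert in general, since both steps start from compounds with no effect at the single concentration tested, and such a read-out cannot show how the change would carry over on a compound with a clear effect. Nor does it speak to any read-out other than this assay.

Only fluoro and methoxy appear on the aromatic ring of the compounds shown, so it stays open whether a nitrile, an amine, a carboxylic acid or a longer chain in that place would lower the number in this assay. Also open, on these data alone, is whether the four compounds would still read alike at a higher concentration, where a difference between the two steps might become visible.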